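A few compounds are considered here, and "the series" means these few. Any claim that something is new, unique, unknown or untested is made for them only; others in the source may bear on it.

Values in a functional assay on HeLa cells (Homo sapiens) for inhibition, read by sulforhodamine B assay; a lower number here means a stronger inhibitor, a higher number a weaker inhibitor:
- compound 1 `O=C1C=C(Nc2cccc(F)c2)C(=O)c2c1nc1n2[C@H]2OC[C@@H](O)[C@H]2OC1`: 6440 nM
- compound 2 `O=C1C=C(NC2CCCC2)C(=O)c2c1nc1n2[C@H]2OC[C@@H](O)[C@H]2OC1`: > 16000 nM (a limit)
- compound 3 `O=C1C=C(Nc2ccc(C(F)(F)F)cc2)C(=O)c2c1nc1n2[C@H]2OC[C@@H](O)[C@H]2OC1`: > 8000 nM (a limit)

Compound 3 stands at > 8000 nM, which is a limit and not a number. Compound 1 is the only one of the three with a measured number.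

Compound 4 `O=C1C=C(Nc2ccc(I)cc2)C(=O)c2c1nc1n2[C@H]2OC[C@@H](O)[C@H]2OC1` follows from iodo in place of trifluoromethyl on an aromatic carbon, with iodo in place of trifluoromethyl on an aromatic carbon, para to a large group. For the measured compounds named here, no measured step makes this exchange itself. The closest is an at least 1.2-fold higher number from compound 1 to compound 3 (0.09 log units; that floor lies within the scatter), also a change of aryl group on the amine nitrogen. The step that the two limits leave unreadable from compound 2 to compound 3 adds nothing, and an at least 2.4-fold higher number from compound 1 to compound 2 (0.39 log units; beyond the scatter) concerns loss of the aryl group, which compound 4 keeps.

With the aryl group kept, compound 4 is expected to lie near compound 1 at 6440 nM or weaker, with no step beyond the scatter. The expected step is an at least 1.1-fold lower number from compound 3 to compound 4 (0.05 log units; that floor lies within the scatter). For compound 4 the estimate is 7000 nM, with an expected range of 2500 nM to 20000 nM.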

Compound 4, half-maximal inhibitory concentration: 4070 nM
Estimate against measurement, compound 4: 1.7-fold (0.24 log units) above; low and high end bracket the measured number.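

In this assay, compound 4 gives a second aryl group on the amine nitrogen with a measured number, and that number stands clear of the cyclopentyl compound: an at least 3.9-fold lower number from compound 2 to compound 4 (0.59 log units; beyond the scatter). Against the only other aryl compound with a measured number, the two aryl groups are not separated: a 1.6-fold lower number from compound 1 to compound 4 (0.20 log units; within the scatter). The exchange of trifluoromethyl for iodo, on an aromatic carbon para to a large group, reads as an at least 1.9-fold lower number from compound 3 to compound 4 (0.29 log units; that floor lies within the scatter), so no change beyond the scatter can be claimed for it, and the value of compound 3 is a limit: the limit of > 8000 nM in this assay, at which 1 of the 4 values shown sits.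

Still open, as far as these compounds go, is how a methoxy, an amine or a carboxylic acid would read in place of iodo, and whether chloro would read like iodo. Also open, from the compounds shown here alone, is how much of the match between compound 1 and compound 4 belongs to the halogen and how much to its place on the ring, as the two compounds differ in both.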